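Swapping Hydroxy for Ethyl on the Aromatic Ring

The source may report more compounds than this note shows. Statements on the series, on what has been measured and on what is new or still open speak of the compounds shown alone.

In a functional assay on 1A9 cells (Homo sapiens) for cytotoxicity (a higher number here means that more compound is needed for the effect, a lower number that less compound is needed), three compounds built on a shared core have been measured so far. Compound 1 `COC1=C(C)C(=O)/C(=C(O)/C=C/c2ccc(OC)cc2)C(=O)C1(C)C` gives 2.8 ug/mL. Compound 2 `COC1=C(C)C(=O)/C(=C(O)/C=C/c2cccc(OC)c2)C(=O)C1(C)C` gives 2.9 ug/mL. Compound 3 `COC1=C(C)C(=O)/C(=C(O)/C=C/c2ccc(O)cc2)C(=O)C1(C)C` gives 2.9 ug/mL. Compound 3 therefore stands level with the other two, and the numbers do not separate any of the three.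

The next structure is compound 4 `CCc1ccc(/C=C/C(O)=C2/C(=O)C(C)=C(OC)C(C)(C)C2=O)cc1`, in which ethyl takes the place of hydroxy on an aromatic carbon: ethyl in place of hydroxy on an aromatic carbon.

The nearest evidence comes from changes at the same part of the molecule. Hydrogen in place of methyl on the oxygen on the aromatic ring gave a 1.0-fold higher number from compound 1 to compound 3 (0.02 log units; within the scatter). Swapping 4-methoxyphenyl for 3-methoxyphenyl gave a 1.0-fold higher number from compound 1 to compound 2 (0.02 log units; within the scatter), and 4-hydroxyphenyl in place of 3-methoxyphenyl gave no change at the digits printed from compound 2 to compound 3 (within the scatter). None of these steps goes beyond the scatter, yet none of them places an ethyl group on the ring, so the data offer only indirect guidance.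

On this evidence, no step beyond the scatter is expected, in either direction. The expected step is no change at the digits printed from compound 3 to compound 4 (within the scatter). Compound 4 is expected to give about 2.9 ug/mL, with an estimated range from 1.5 ug/mL to 5.5 ug/mL.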

Compound 4, concentration for half-maximal effect: 5.3 ug/mL
Estimate against measurement, compound 4: 1.8-fold (0.26 log units) below, within the range that was stated.
By their numbers in this assay, from the lowest: compounds 1, 2, 3 and 4 (each within the scatter of the next).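

In this assay, within the data shown here, compounds 1, 2 and 3 all carry an oxygen on the aromatic ring, so they could not show whether that oxygen matters; compound 4 is the first with only carbon there, and the step (a 1.8-fold higher number from compound 3 to compound 4 (0.26 log units; within the scatter)) shows that ethyl can replace hydroxy at this position, para to a large group, without leaving the scatter. This swap removes the one hydrogen-bond donor and one hydrogen-bond acceptor counted for hydroxy, and the comparisons with the two methoxy compounds read the same way (a 1.8-fold higher number from compound 2 to compound 4 (0.26 log units; within the scatter)) and (a 1.9-fold higher number from compound 1 to compound 4 (0.28 log units; within the scatter)), so across these four compounds the number does not depend measurably on an oxygen being attached to the ring. Nothing measured alongside these numbers shows what lies behind them.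

As far as these compounds go, every step among the four compounds stays within the scatter, so it remains open which group on this ring, if any, would move the number clearly in either direction. An amine, a carboxylic acid or a longer chain such as butyl in place of the ethyl would test how far this tolerance extends.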